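From cyclopentylamino to benzylamino on a shared core

This account rests on a few compounds, and the source may have more. Where it says the series, first, only, none or still open, it means among the compounds named here.

Compound 1 `O=C1C(NC2CCCC2)=CC(=O)c2c1nc1n2[C@H]2OC[C@@H](O)[C@H]2OC1` gives in a functional assay on HeLa cells (Homo sapiens) for inhibition, read by sulforhodamine B assay (a lower number here means a stronger inhibitor, a higher number a weaker inhibitor), only a limit, > 16000 nM, and not a number. Compound 2 `CCc1ccc(NC2=CC(=O)c3nc4n(c3C2=O)[C@H]2OC[C@@H](O)[C@H]2OC4)cc1`, built on the same core, gives 3990 nM in this assay. Among the measured compounds shown here, no step between measured compounds is available. Compound 3 `O=C1C(NCc2ccccc2)=CC(=O)c2c1nc1n2[C@H]2OC[C@@H](O)[C@H]2OC1` differs from compound 1 by benzyl in place of cyclopentyl on an amine nitrogen. Since compound 1 sits at the limit of > 16000 nM in this assay, at which 1 of the 2 values shown sits, the step can only be seen if compound 3 returns a number. A modest gain is expected, an at least 1.7-fold lower number from compound 1 to compound 3 (0.24 log units; that floor lies within the scatter), though the outcome may again be a limit. Compound 3 is estimated at 9000 nM, in the range 2500 nM to 30000 nM.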

Compound 3, half-maximal inhibitory concentration: 11000 nM
Compound 3: the middle estimate sits 1.2-fold (0.09 log units) below what was measured; measured number inside the range.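

In this assay compound 3 gives 11000 nM, so with benzyl on this amine nitrogen the shared core returns a number and not a limit. The change from cyclopentyl to benzyl reads as an at least 1.4-fold lower number from compound 1 to compound 3 (0.16 log units; that floor lies within the scatter), so the step is not established as real. Its full size stays unknown because compound 1 stands at a limit and not at a number: the limit of > 16000 nM in this assay, at which 1 of the 3 values shown sits.

The compounds shown leave open how a longer chain such as phenethyl, or a benzyl carrying a methoxy group, would read on this nitrogen. They also leave open whether cyclohexyl would return a number.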